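Benzylsulfanyl in place of hexylsulfanyl: expected cytotoxicity

The source may hold more compounds than are shown below. What is called first, only, known or untested is meant among the compounds shown, and "the series" means these compounds.

The three measured compounds share one core and differ at a single aromatic carbon. Compound 1 `Nc1nc(NC2CC2)c2ncn(/C=C3/CC3(CO)CO)c2n1` carries cyclopropylamino there, and in an ADME assay on BCBL1 cells (Homo sapiens) for cytotoxicity, with a stated time of 7 days (on this read-out lower numbers stand for higher toxicity in this test and higher numbers for lower toxicity in this test), compound 1 gives 71500 nM. Compound 2 `CCCCCCSc1nc(N)nc2c1ncn2/C=C1/CC1(CO)CO` carries hexylsulfanyl instead. In this assay compound 2 gives only a limit, > 20000 nM. Compound 3 `Nc1nc(SC2CCCC2)c2ncn(/C=C3/CC3(CO)CO)c2n1` carries cyclopentylsulfanyl. In this assay compound 3 also gives only a limit, > 20000 nM. Because of the limit of > 20000 nM in this assay, at which 2 of the 3 values shown sit, the steps a step that the limit leaves unreadable from compound 1 to compound 2, a step that the limit leaves unreadable from compound 1 to compound 3 and a step that the two limits leave unreadable from compound 2 to compound 3 cannot be sized; nothing in them can be separated from the scatter.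

Compound 4 `Nc1nc(SCc2ccccc2)c2ncn(/C=C3/CC3(CO)CO)c2n1` has not been measured. It differs from compound 2 in one place: phenyl in place of pentyl on a saturated chain carbon bound to a sulfur. For the measured compounds named here, the only measured step that touches the group on the sulfur is the one from compound 2 to compound 3, and it is unreadable; compound 2 itself stands at the limit. Going by the values given here, no measured step therefore points in either direction, and the expected step that the limit leaves unreadable from compound 2 to compound 4 is one within the scatter. Compound 4 is estimated at 40000 nM in this assay, with a range from 15000 nM to 120000 nM, and the most likely report is again a limit.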

Compound 4, half-maximal cytotoxic concentration: > 20000 nM
Compound 4 gave a limit, no number (the forecaster's own chance of this, stated with the estimate: 70%); the middle value does not contradict the limit.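

Compound 4 also gives only a limit in this assay, and none of the steps linking compound 1, compound 2, compound 3 and compound 4 can be read because of one shared ceiling: the limit of > 20000 nM in this assay, at which 3 of the 4 values shown sit.

Going by these compounds, whether hexylsulfanyl, cyclopentylsulfanyl and benzylsulfanyl differ from one another in this assay stays open, as does how each compares with cyclopropylamino.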